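Trimming the ether chain of compound 3

This account rests on a few compounds, and the source may have more. Where it says the series, first, only, none or still open, it means among the compounds named here.

Compound 1 `CCSc1nc(C)c(-c2ccnc(Nc3ccc(OC)cc3OC)n2)s1`: in a functional assay on MV4-11 cells (Homo sapiens) for inhibition, read by resazurin assay, with a stated time of 72 h (a higher number here means a weaker inhibitor of growth, a lower number a stronger inhibitor of growth), compound 1 gives 32400 nM.
Compound 2 `CCCCOc1nc(C)c(-c2ccnc(Nc3ccc(OC)cc3OC)n2)s1`: in this assay compound 2 gives 7860 nM.
Compound 3 `COCCOc1nc(C)c(-c2ccnc(Nc3ccc(OC)cc3OC)n2)s1`: in this assay compound 3 gives 1980 nM.

Compound 3 stands at the lowest number of the three, with a 4.0-fold lower number from compound 2 to compound 3 (0.60 log units; beyond the scatter) and a 16-fold lower number from compound 1 to compound 3 (1.21 log units; beyond the scatter). Compound 4 `COc1ccc(Nc2nccc(-c3sc(OC)nc3C)n2)c(OC)c1` differs from compound 3 by hydrogen in place of methoxymethyl on a saturated chain carbon bound to an oxygen on an aromatic ring. Among the measured compounds shown here, no measured step cuts a chain in this way; the closest comparison is a 4.0-fold lower number from compound 2 to compound 3 (0.60 log units; beyond the scatter), which shows that the methoxy at the chain end carried a modest gain, while a 4.1-fold lower number from compound 1 to compound 2 (0.62 log units; beyond the scatter) concerns a different part of the chain. With that methoxy removed along with the carbon bearing it, a modest rise in the number is expected, though with wide uncertainty. Compound 4 is therefore estimated at 5000 nM, between 1500 nM and 16000 nM, an expected step of a 2.5-fold higher number from compound 3 to compound 4 (0.40 log units; beyond the scatter).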

Compound 4, concentration for 50% growth inhibition: 1400 nM
The estimate for compound 4 lay 3.6-fold (0.55 log units) above the measured number; measured number below the stated range.
By their numbers in this assay, from the lowest: compounds 4 and 3 (each within the scatter of the next); then compound 2; then compound 1.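

In this assay, the step from 2-methoxyethoxy to methoxy is a 1.4-fold lower number from compound 3 to compound 4 (0.15 log units; within the scatter), so the methoxymethyl is not needed to keep the number at this level. The methoxy ether also stands clear of butoxy (a 5.6-fold lower number from compound 2 to compound 4 (0.75 log units; beyond the scatter)) and of ethylsulfanyl (a 23-fold lower number from compound 1 to compound 4 (1.36 log units; beyond the scatter)), and chain length alone does not order the ethers, since butoxy sits apart while the longer 2-methoxyethoxy and the shorter methoxy remain level. Nothing available explains these differences.

The compounds shown leave open whether an amine or a 3-methoxypropoxy chain at this aromatic carbon would hold these numbers.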